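This account rests on a few compounds, and the source may have more. Where it says the series, first, only, none or still open, it means among the compounds named here.

Within the data shown here, in a functional assay on MDA-MB-231 cells (Homo sapiens), read by wound healing assay, with a stated time of 24 h (on this read-out higher numbers stand for weaker inhibition and lower numbers for stronger inhibition), compound 1 (`CC(=O)O[C@H]1CC[C@]2(C)[C@H](CC[C@@](C)(O)[C@H]2CC[C@@H]2C(C)=CC[C@@H]3C(C)=CC[C@@H]3C2(C)C)OC1(C)C`) gives 16000 nM; 16000 nM (2 entries) on both of its readings, and compound 2 (`CC1=CC[C@H]2[C@@H]1CC=C(C)[C@@H](CC[C@H]1[C@]3(C)CC[C@H](OC(=O)CCC(=O)O)C(C)(C)O[C@H]3CC[C@@]1(C)O)C2(C)C`) gives 21000 nM on its single reading. These two values lie within the usual scatter of each other, so compound 2 stands level with compound 1 and the numbers set no order between them. Compound 3 (`CC1=CC[C@H]2[C@@H]1CC=C(C)[C@@H](CC[C@H]1[C@]3(C)CC[C@H](OC(=O)c4ccc(Cl)cc4)C(C)(C)O[C@H]3CC[C@@]1(C)O)C2(C)C`) has not yet been measured. It departs from compound 2 in one place: 4-chlorophenyl in place of 2-carboxyethyl on a carbonyl carbon. A chain with a hydrogen-bond donor and a hydrogen-bond acceptor thus gives way to a six-membered aromatic ring of carbon only. Among the measured compounds shown here, no step between measured compounds offers a guide to this change, so the expectation is tentative. A modest move toward stronger inhibition in this assay is expected, only a little beyond the scatter, and the estimated change a 2.3-fold lower number from compound 2 to compound 3 (0.37 log units; beyond the scatter) reflects that. The estimate for compound 3 is 9000 nM (expected range 3000 nM to 25000 nM).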

Compound 3, half-maximal inhibitory concentration: 5900 nM
For compound 3 the middle estimate is 1.5-fold (0.18 log units) above the measured one; low and high end bracket the measured number.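

In this assay the group on this carbonyl carbon now makes a measurable difference: 4-chlorophenyl in place of 2-carboxyethyl gives a 3.6-fold lower number from compound 2 to compound 3 (0.55 log units; beyond the scatter) and so goes with stronger inhibition. Among these compounds, compound 1 and compound 2 stood level and set no order, so this is the first step to lie beyond the scatter, although it remains a modest one. It also shows that a chain with a hydrogen-bond donor and a hydrogen-bond acceptor is not needed at this position for the inhibition seen here, since the six-membered aromatic ring of carbon only that replaces it carries neither, and no evidence is available to explain the lower number.

Whether the ring or the chlorine accounts for the step remains open, and a plain phenyl group on the same carbonyl carbon would be the direct test of that. Also open, from the compounds shown here alone, is how a 4-methoxyphenyl group, a 3-chlorophenyl group or a chain ending in an amine would compare at this position.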